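The source may hold more compounds than are shown below. What is called first, only, known or untested is meant among the compounds shown, and "the series" means these compounds.

Compound 1, with the structure `COc1ccc(-c2cc(/C=C/C(=O)c3ccc(N)cc3)[nH]n2)cc1`, carries an aminophenyl ketone on one side of its enone and a methoxyphenyl group on the other. In a functional assay on MCF7 cells (Homo sapiens) for cytotoxicity, read by sulforhodamine B assay, with a stated time of 48 h, tested at 100 uM (on this read-out higher numbers stand for a weaker effect at the one concentration tested and lower numbers for a stronger effect), compound 1 gives -68%. Compound 3, with the structure `COc1ccc(-c2cc(/C=C/C(=O)c3ccc(N)cc3)[nH]n2)cc1OC`, keeps that whole skeleton and differs only by methoxy in place of hydrogen on an aromatic carbon. In this assay compound 3 gives -58%; the step of a number 10 percentage points higher from compound 1 to compound 3 (within the scatter) is reported as lying within the scatter of the measurement.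

Compound 2, with the structure `COc1ccc(C(=O)/C=C/c2cc(-c3cc(OC)c(OC)c(OC)c3)n[nH]2)cc1OC`, belongs to a different core, in which the enone is reversed and a trimethoxyphenyl group sits on the pyrazole; the difference between the two cores is not broken down here. In this assay compound 2 gives -66%, which falls within the scatter of the values of compound 1 and of compound 3.

Compound 4, with the structure `COc1cc(C(=O)/C=C/c2cc(-c3cc(OC)c(OC)c(OC)c3)n[nH]2)cc(OC)c1OC`, has not yet been measured. It differs from compound 2 by methoxy in place of hydrogen on an aromatic carbon. This is the same kind of change as from compound 1 to compound 3, though the surroundings are not identical: in compound 4 the place is also meta to a methoxy group (2 heavy atoms), which is not the case in compound 3. For the measured compounds named here, since the one measured instance of this change, a number 10 percentage points higher from compound 1 to compound 3 (within the scatter), stayed within the scatter, the step of a number 8 percentage points higher from compound 2 to compound 4 (within the scatter) is expected to be small as well. Compound 4 is therefore estimated at -58%, with a likely range from -76% to -38%.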

Compound 4, a percentage reported as activity, at one concentration (the size of the read-out at that concentration, not a potency): -72%
For compound 4 the middle estimate is 14 percentage points above the measured one; measured number inside the range.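

In this assay, methoxy in place of hydrogen on an aromatic carbon gives a number 6 percentage points lower from compound 2 to compound 4 (within the scatter), so on this core, taken alone, the change shows no effect that stands clear of the usual scatter. Set beside the earlier instance, the two steps do not agree, and the change did not carry over from one core to the other as a fixed shift: the same change on two cores in this assay, a number 10 percentage points higher (within the scatter) from compound 1 to compound 3 and a number 6 percentage points lower (within the scatter) from compound 2 to compound 4, 16 percentage points apart, beyond the scatter of two such steps This does not show why the steps part, or that either step alone is a real effect: each rests on one pair, the cores differ in more than one place, and the new methoxy in compound 4 is meta to a methoxy group, unlike the one in compound 3.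

The compounds shown leave open whether a hydroxy group or a chlorine atom in the same place would also give steps that differ between the two cores, as methoxy does here. Also open, on these data alone, is how any of these steps would look as a potency, as the read-out gives only the size of the effect at one concentration in one cell line.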